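This account rests on a few compounds, and the source may have more. Where it says the series, first, only, none or still open, it means among the compounds named here.

Measured compounds:
- Compound 1, `NCCC(=O)Nc1cccc2c1cnn2S(=O)(=O)c1cccc2ccccc12`, in a functional assay on HeLa cells for antagonist activity at 5-hydroxytryptamine receptor 6 (Homo sapiens), read by cAMP accumulation (a lower number here means a stronger inhibitor, a higher number a weaker inhibitor), gives 11 nM.
- Compound 2, `CN(C)CCC(=O)Nc1ccc2cnn(S(=O)(=O)c3cccc4ccccc34)c2c1`, in this assay gives 53 nM.

Of these two numbers, compound 2 holds the higher one, and the gap to compound 1 lies beyond the usual scatter, so compound 2 is the weaker inhibitor of the pair. Compound 3, `CCN(CC)CCC(=O)Nc1ccc2cnn(S(=O)(=O)c3cccc4ccccc34)c2c1`, has not yet been measured. It is built from compound 2 by one change: diethylamino in place of dimethylamino on a saturated chain carbon, two bonds along the chain from a carbonyl carbon. Both compounds keep the same shared core and the same chain to the basic amine; only the two small groups on that nitrogen grow. Such a change is expected to move the number only a little, in either direction, most likely staying within the scatter. From compound 2 to compound 3 the step expected in this assay is a 1.0-fold higher number from compound 2 to compound 3 (0.02 log units; within the scatter). For compound 3 the estimated value in this assay is 55 nM, within a range from 20 nM to 160 nM.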

Compound 3, half-maximal inhibitory concentration: 260 nM
Beside the measured number, compound 3's estimate is 4.7-fold (0.67 log units) below it; measured number above the stated range.
By their numbers in this assay, from the lowest: compound 1; then compound 2; then compound 3.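

In this assay, replacing dimethylamino with diethylamino gives a 4.9-fold higher number from compound 2 to compound 3 (0.69 log units; beyond the scatter). So the groups on this nitrogen are not interchangeable: growing from 3 heavy atoms to 5, with no ring added and no change in the count of hydrogen-bond donors or acceptors, is enough to weaken inhibition beyond the scatter. Compound 1 and compound 2 differ in more than one place and could not show this, and no measurement here bears on why the number rose.

This single step does not establish a trend with group size. As far as these compounds go, it remains open where a plain amino group, a single ethyl group, a pyrrolidine or piperidine ring on the nitrogen, or a longer chain would fall relative to compound 2 and compound 3.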